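Exchanging the dimethylamino for dimethylcarbamoyl on the shared core

The compounds below may be only part of what the source reports. "The series", "measured", "known", "first", "only" and "open" are said of these compounds alone.

Compound 2 `CN(C)c1ccc(NC(=S)N2CCC(C(O)(c3ccccc3)c3ccccc3)CC2)cc1` carries a 4-(dimethylamino)phenyl group on the shared core. In a functional assay for antagonist activity at Neuropeptide Y receptor type 2 (Homo sapiens) (a higher number here means a weaker inhibitor, a lower number a stronger inhibitor), compound 2 gives 612 nM. Its only measured relative, compound 1 `OC(c1ccccc1)(c1ccccc1)C1CCN(C(=S)Nc2ccc(OC(F)(F)F)cc2)CC1`, gives 1050 nM in this assay, and the step of a 1.7-fold lower number from compound 1 to compound 2 (0.23 log units; within the scatter) keeps the two together, so neither stands apart. Compound 3 `CN(C)C(=O)c1ccc(NC(=S)N2CCC(C(O)(c3ccccc3)c3ccccc3)CC2)cc1` differs from compound 2 by dimethylcarbamoyl in place of dimethylamino on an aromatic carbon. Among the compounds with values here, the single known step, from compound 1 to compound 2, altered the group on this aromatic carbon without moving beyond the scatter, so no shift beyond the scatter is expected here either. Compound 3 is therefore expected near 800 nM, between 250 nM and 2500 nM, a change of a 1.3-fold higher number from compound 2 to compound 3 (0.12 log units; within the scatter).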

Compound 3, half-maximal inhibitory concentration: 301 nM
The estimate for compound 3 lay 2.7-fold (0.42 log units) above the measured number; low and high end bracket the measured number.
By their numbers in this assay, from the lowest: compound 3; then compounds 2 and 1 (each within the scatter of the next).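

Within the data shown here, with dimethylcarbamoyl on this aromatic carbon, para to a large group, a 2.0-fold lower number from compound 2 to compound 3 (0.31 log units; beyond the scatter) in this assay is the first step here to pass the scatter, though only modestly. The wider a 3.5-fold lower number from compound 1 to compound 3 (0.54 log units; beyond the scatter) shows that the choice of group at this position can separate these compounds, and among the three groups shown, dimethylcarbamoyl gives the lowest number. No measurement here explains this difference. From the compounds shown here alone, whether a carboxylic acid, a primary amide or a longer chain at this position would lower the number further remains open.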